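Azido Nucleosides: Chloro for Amino on the Base

The source may hold more compounds than are shown below. What is called first, only, known or untested is meant among the compounds shown, and "the series" means these compounds.

The series concerns azido sugar nucleosides that differ in the substituents on the base. Compound 1 `[N-]=[N+]=N[C@H]1C[C@H](n2cnc3c(N)nc(F)nc32)O[C@@H]1CO` gives 30100 nM in an ADME assay on PBMC cells (Homo sapiens) for cytotoxicity, with a stated time of 5 days; on this read-out lower numbers stand for stronger inhibition and higher numbers for weaker inhibition; among the two numbers recorded it is the lowest, with compound 3 `COc1nc(N)c2ncn([C@H]3C[C@H](N=[N+]=[N-])[C@@H](CO)O3)c2n1` nearest at 35000 nM. Among the measured compounds shown here, the one measured step, methoxy in place of fluoro on an aromatic carbon, is a 1.2-fold higher number from compound 1 to compound 3 (0.07 log units; within the scatter). Compound 2 `CN(C)c1nc(Cl)nc2c1ncn2[C@H]1C[C@H](N=[N+]=[N-])[C@@H](CO)O1` reaches only the limit of this assay, > 100000 nM, and this is a limit rather than a number (the limit of > 100000 nM in this assay, at which 1 of the 3 values shown sits).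

Compound 4 `[N-]=[N+]=N[C@H]1C[C@H](n2cnc3c(Cl)nc(F)nc32)O[C@@H]1CO` is not yet measured. It differs from compound 1 by chloro in place of amino on an aromatic carbon. For the measured compounds named here, no measured step changes the amino group, and compound 2 carries chloro together with dimethylamino, a pair for which no step to compound 1 is recorded, so its limit only shows that a chloro-bearing analogue can fall outside the measurable range. Going by the values given here, the single measured step lies within the scatter and gives no direction for the present change.

The expectation is therefore a number near that of compound 1, with wide uncertainty toward weaker inhibition: compound 4 is estimated at 40000 nM, between 10000 nM and 150000 nM, so that the expected step is a 1.3-fold higher number from compound 1 to compound 4 (0.12 log units; within the scatter).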

Compound 4, half-maximal inhibitory concentration: 7200 nM
The estimate for compound 4 lay 5.6-fold (0.74 log units) above the measured number, and the stated range ends above it.
By their numbers in this assay, from the lowest: compound 4; then compounds 1 and 3 (each within the scatter of the next). At a limit, above all of these: compound 2.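

In this assay, among the compounds shown here, the aromatic carbon meta to the fluoro group is the first place where a single change moves the number beyond the scatter, with chloro in place of amino (a 4.2-fold lower number from compound 1 to compound 4 (0.62 log units; beyond the scatter)). For the compounds shown here, the only earlier step, methoxy in place of fluoro on the other substituted carbon, stayed within the scatter (a 1.2-fold higher number from compound 1 to compound 3 (0.07 log units; within the scatter)), so the series does respond to the base substituents, at least at this carbon. The amino group is also not needed for a measurable number, since compound 4 without it gives 7200 nM, though nothing measured here gives a property of either group and no cause can be assigned to the step.

On these data alone, whether the lower number is particular to chloro remains open, as bromo, methyl, a thioether or a hydroxy group at this carbon would be needed to show how far the trend extends. Also open, as far as these compounds go, is whether the step holds with methoxy in place of the fluoro group, which would show whether the two changes act independently.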